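The source may report more compounds than this note shows. Statements on the series, on what has been measured and on what is new or still open speak of the compounds shown alone.

Compound 1 `Fc1ccc(-c2nn3c(NC4CCCC4)cccc3c2-c2ccnc(NC3CCCC3)n2)cc1` was tested in an ADME assay on Vero cells (Chlorocebus sabaeus) for cytotoxicity (on this read-out higher numbers stand for lower toxicity in this test and lower numbers for higher toxicity in this test), and reached only the limit of the test, giving > 160000 nM; this is a limit, not a number, as the note the limit of > 160000 nM in this assay, at which 1 of the 2 values shown sits, states. Compound 2 `Nc1ccn2nc(-c3ccc(F)cc3)c(-c3ccnc(NC4CCCC4)n3)c2c1`, with a different core, gives 20000 nM in this assay. Compound 3 `c1cc(NC2CCCC2)n2nc(-c3ccc(OCC4CC4)cc3)c(-c3ccnc(NC4CCCC4)n3)c2c1` carries the change (cyclopropylmethoxy in place of fluoro on an aromatic carbon), so the group leaving is a single fluorine and the group entering is a larger chain with a small ring. Going by the values given here, with no measured step to rest on, the expected step of an at least 2.0-fold lower number from compound 1 to compound 3 (0.30 log units; that floor lies within the scatter) is a modest move toward greater toxicity, beyond the scatter but not large. Compound 3 is therefore estimated at 80000 nM, with a likely range from 25000 nM to 200000 nM in this assay.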

Compound 3, half-maximal cytotoxic concentration: > 40000 nM
Compound 3: a limit, no number; the forecaster's own chance of this, stated with the estimate: 40%; the middle value is on the limit's open side.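

Going by these compounds alone, the results for compound 1 and compound 3 are both limits, not numbers, so no step between them can be read. Going by these compounds, whether cyclopropylmethoxy in place of fluoro changes the result in this assay stays open, in size and in direction.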